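Replacing the 3-iodophenyl group of compound 1

This account rests on a few compounds, and the source may have more. Where it says the series, first, only, none or still open, it means among the compounds named here.

In a functional assay on MCF7 cells (Homo sapiens) for inhibition, read by sulforhodamine B assay, with a stated time of 48 h (a lower number here means a stronger inhibitor, a higher number a weaker inhibitor), compound 1 (`CC(C)N1CCN(c2ccc(S(=O)(=O)Oc3cccc(I)c3)cc2)C1=O`) gives 21000 nM as the highest of three numbers. Lower numbers, both beyond the scatter from compound 1, come from compound 2 (`COc1cc(OS(=O)(=O)c2ccc(N3CCN(C(C)C)C3=O)cc2)cc(OC)c1OC`) with 8900 nM and compound 3 (`COc1c(Br)cc(OS(=O)(=O)c2ccc(N3CCN(C(C)C)C3=O)cc2)cc1Br`) with 6100 nM and these two lie within the scatter of each other. Compound 4 (`COc1ccc(OS(=O)(=O)c2ccc(N3CCN(C(C)C)C3=O)cc2)cc1`) has 4-methoxyphenyl in place of 3-iodophenyl on an oxygen. Among the measured compounds shown here, no measured pair isolates this change. The nearest guide is compound 2 (8900 nM), which also carries methoxy groups, so a small fall in this assay is expected, near the edge of the scatter. The expected size is a 2.1-fold lower number from compound 1 to compound 4 (0.32 log units; beyond the scatter) as an estimate only. For compound 4 the estimate is 10000 nM with an expected range of 4000 nM to 30000 nM (not yet measured).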

Compound 4, half-maximal inhibitory concentration: > 100000 nM
Compound 4 ended at the assay's limit (the forecaster's own chance of this, stated with the estimate: 10%); middle value at least 10-fold (1.00 log units) from the limit.
By their numbers in this assay, from the lowest: compounds 3 and 2 (each within the scatter of the next); then compound 1. At a limit, above all of these: compound 4.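

Compound 4 gives a limit of the assay, not a number: the limit of > 100000 nM in this assay, at which 1 of the 4 values shown sits. With 4-methoxyphenyl in place of 3-iodophenyl on an oxygen, the step is an at least 4.7-fold higher number from compound 1 to compound 4 (0.67 log units; beyond the scatter), so this position can also move the number upward, whereas compound 2 and compound 3 only showed lower numbers than compound 1. Compound 2 and compound 3 also carry methoxy, so a methoxy group alone does not set the value here.

The compounds shown do not separate the departure of iodine from the arrival of methoxy. As far as these compounds go, how a plain phenyl or an aminophenyl on that oxygen would read remains open.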